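Sulfonylpiperidine series: replacing the second piperidine ring

This account rests on a few compounds, and the source may have more. Where it says the series, first, only, none or still open, it means among the compounds named here.

In a functional assay on DLD-1 cells (Homo sapiens) for antiproliferative activity, read by CellTiter-Glo, with a stated time of 72 h (on this read-out lower numbers stand for stronger inhibition and higher numbers for weaker inhibition), compound 1 `CC1CCN(C2CCN(S(=O)(=O)c3cccc(Br)c3)CC2)CC1` gives 3.2 nM, and compound 2 `Cc1cc(C)c(S(=O)(=O)N2CCC(N3CCC(CCO)CC3)CC2)c(C)c1` gives 19 nM, so compound 2 carries the higher of the two numbers, with a gap beyond the usual scatter. Compound 3 `COC(=O)c1ccc(S(=O)(=O)N2CCC(N3CCC(C)CC3)CC2)cc1` reaches only a limit of this assay, > 5000 nM; this is the limit of > 5000 nM in this assay, at which 1 of the 3 values shown sits. Compound 4 `Cc1ccc(C2CCN(S(=O)(=O)c3c(C)cc(C)cc3C)CC2)cc1` is not yet measured and differs from compound 2 in one place: 4-methylphenyl in place of 4-(2-hydroxyethyl)piperidin-1-yl on a saturated ring carbon. For the measured compounds named here, no measured pair shows this change, so the step can only be expected, not read off. The step expected in this assay is a 26-fold higher number from compound 2 to compound 4 (1.42 log units; beyond the scatter), toward weaker inhibition and beyond the scatter, though with wide uncertainty. Compound 4 is estimated at 500 nM, with a range from 50 nM to 5000 nM.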

Compound 4, half-maximal inhibitory concentration: 2200 nM
Beside the measured number, compound 4's estimate is 4.4-fold (0.64 log units) below it, and the stated range covers the measured number.
By their numbers in this assay, from the lowest: compound 1; then compound 2; then compound 4. At a limit, above all of these: compound 3.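

On the saturated ring carbon, 4-methylphenyl in place of 4-(2-hydroxyethyl)piperidin-1-yl gives a 120-fold higher number from compound 2 to compound 4 (2.06 log units; beyond the scatter) in this assay, so this position does not accept every six-membered ring equally. For the compounds shown here, the change removes the ring nitrogen and the hydroxyethyl chain together, so the single step cannot be assigned to either one. Compound 4 still gives a number and is not at a limit: the limit of > 5000 nM in this assay, at which 1 of the 4 values shown sits.

It remains open which of the two parts accounts for the step. A phenyl ring bearing a 2-hydroxyethyl chain, or a 4-methylpiperidin-1-yl at this place on the same mesityl sulfonyl core, would separate them.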